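Bromo Substitution on Two Oxindole Glycoside Cores in Cytotoxicity

A few compounds are considered here, and "the series" means these few. Any claim that something is new, unique, unknown or untested is made for them only; others in the source may bear on it.

Compound 1 `CCCC(=O)c1ccc2c(c1)/C(=C1\C(=O)N([C@@H]3O[C@H](COC(C)=O)[C@@H](OC(C)=O)[C@H](OC(C)=O)[C@H]3OC(C)=O)c3ccccc31)C(=O)N2` and compound 2 `CCCC(=O)c1ccc2c(c1)/C(=C1\C(=O)N([C@@H]3O[C@H](COC(C)=O)[C@@H](OC(C)=O)[C@H](OC(C)=O)[C@H]3OC(C)=O)c3ccc(Br)cc31)C(=O)N2` share one core, while compound 3 `CC(=O)OC[C@H]1O[C@@H](N2C(=O)/C(=C3/C(=O)Nc4ncccc43)c3ccccc32)[C@H](OC(C)=O)[C@@H](OC(C)=O)[C@@H]1OC(C)=O` and compound 4 `CC(=O)OC[C@H]1O[C@@H](N2C(=O)/C(=C3/C(=O)Nc4ncc(Br)cc43)c3ccccc32)[C@H](OC(C)=O)[C@@H](OC(C)=O)[C@@H]1OC(C)=O` share another; the difference between the two cores is not broken down here. In an ADME assay on L6 cells (Rattus norvegicus) for cytotoxicity, read by resazurin assay, with a stated time of 72 h (on this read-out lower numbers stand for stronger inhibition and higher numbers for weaker inhibition), compound 1 gives 31700 nM, compound 2 gives 99000 nM, and compound 3 gives 27400 nM. The change from compound 1 to compound 2 is bromo in place of hydrogen on an aromatic carbon, and it brought a 3.1-fold higher number from compound 1 to compound 2 (0.49 log units; beyond the scatter). The change from compound 3 to compound 4 is bromo in place of hydrogen on an aromatic carbon. It is the same kind of change, not the same: in compound 2 the bromo sits on a six-membered aromatic ring of carbon only, whereas in compound 4 it sits on a six-membered aromatic ring with 1 nitrogen, two atoms from the ring nitrogen. Because of a 3.1-fold higher number from compound 1 to compound 2 (0.49 log units; beyond the scatter), a step of similar direction is expected from compound 3 to compound 4 in this assay, namely a 2.6-fold higher number from compound 3 to compound 4 (0.41 log units; beyond the scatter). The value of compound 4 is therefore estimated at 70000 nM, within a range from 35000 nM to 150000 nM.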

Compound 4, half-maximal inhibitory concentration: 26100 nM
The estimate for compound 4 lay 2.7-fold (0.43 log units) above the measured number; measured number outside the range, below it.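

In this assay, the step seen on the core of compound 1 did not recur on the core of compound 3, where bromo in place of hydrogen on an aromatic carbon gave a 1.0-fold lower number from compound 3 to compound 4 (0.02 log units; within the scatter), so compound 3 and compound 4 cannot be told apart, and the two steps differ by more than their scatter allows: the same change on two cores in this assay, a 3.1-fold higher number (0.49 log units; beyond the scatter) from compound 1 to compound 2 and a 1.0-fold lower number (0.02 log units; within the scatter) from compound 3 to compound 4, 3.3-fold (0.52 log units) apart, beyond the scatter of two such steps. This shows that, in this series, the step found on one core cannot simply be carried to the other. It does not show why, since the two pairs differ in both core and ring: the bromo stands on a six-membered aromatic ring of carbon only in compound 2 and on a six-membered aromatic ring with 1 nitrogen in compound 4.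

Still open, from the compounds shown here alone, is whether bromo on the carbon-only ring of the core of compound 3 would behave as in compound 2, which would help separate the ring from the rest of the core. Also open, going by these compounds, is whether chloro or methoxy in place of bromo would follow either step.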